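Cytotoxicity notes: aryl swap on the triazole nitrogen

The compounds below may be only part of what the source reports. "The series", "measured", "known", "first", "only" and "open" are said of these compounds alone.

Measured so far in a toxicity assay on PC-12 cells (Rattus norvegicus) for cytotoxicity, read by MTT assay; on this read-out higher numbers stand for weaker inhibition and lower numbers for stronger inhibition:
compound 1, `CC(C)c1ccc(-n2nc(-c3ccc(C(F)(F)F)cc3O)nc2-c2ccccc2O)cc1`, gives 144000 nM
compound 2, `Oc1cc(C(F)(F)F)ccc1-c1nc(-c2ccccc2O)n(-c2cccc(C(F)(F)F)c2)n1`, gives 49700 nM

Within the data shown here, compound 2 holds the lower of the two numbers in this assay; its only neighbour is compound 1, and the gap is a 2.9-fold lower number from compound 1 to compound 2 (0.46 log units; beyond the scatter), a modest step that lies beyond the scatter.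

Compound 3, `Oc1cc(C(F)(F)F)ccc1-c1nc(-c2ccccc2O)n(-c2cc(F)cc(F)c2)n1`, is unmeasured. (3,5-difluorophenyl in place of 3-(trifluoromethyl)phenyl on an aromatic nitrogen). Among the measured compounds shown here, the one step that bears on this is the same kind of change, an aryl swap on the same aromatic nitrogen, where a 2.9-fold lower number from compound 1 to compound 2 (0.46 log units; beyond the scatter); the groups exchanged there differ from the present pair, so the direction is not fixed by the data. The expected outcome for compound 3 is a step of a 1.2-fold higher number from compound 2 to compound 3 (0.08 log units; within the scatter), within the scatter. Compound 3 is estimated at 60000 nM in this assay, with a range from 20000 nM to 180000 nM.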

Compound 3, half-maximal inhibitory concentration: 53700 nM
Compound 3: middle estimate off by 1.1-fold (0.05 log units), on the high side; the measured number falls inside the stated range.
By their numbers in this assay, from the lowest: compounds 2 and 3 (each within the scatter of the next); then compound 1.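

Exchanging 3-(trifluoromethyl)phenyl for 3,5-difluorophenyl on the aromatic nitrogen gives no readable change in this assay (a 1.1-fold higher number from compound 2 to compound 3 (0.03 log units; within the scatter)), so these two aryl groups cannot be told apart at this position on this read-out. Compound 3 also stands apart from compound 1 (a 2.7-fold lower number from compound 1 to compound 3 (0.43 log units; beyond the scatter)), so the separation of 4-isopropylphenyl from the other aryl group now holds for two replacements rather than one, though the step remains modest. No accompanying measurement speaks to why the numbers fall this way.

As far as these compounds go, an aryl group on this nitrogen carrying an amine or a carboxylic acid remains open, as does a plain alkyl chain in place of the aryl ring. The compounds shown also leave open whether either hydroxyl group on the shared core matters for this read-out.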